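Swapping an aryl for a benzyl on the amine nitrogen

The source may report more compounds than this note shows. Statements on the series, on what has been measured and on what is new or still open speak of the compounds shown alone.

Measured compounds in a functional assay on HeLa cells (Homo sapiens) for inhibition, read by sulforhodamine B assay; a higher number here means a weaker inhibitor, a lower number a stronger inhibitor:
compound 1 `O=C1C=C(Nc2ccc(I)cc2)C(=O)c2c1nc1n2[C@H]2OC[C@@H](O)[C@H]2OC1`: 4070 nM
compound 2 `COc1cccc(NC2=CC(=O)c3c(nc4n3[C@H]3OC[C@@H](O)[C@H]3OC4)C2=O)c1`: > 8000 nM
compound 3 `O=C1C(N2CCCCC2)=CC(=O)c2c1nc1n2[C@H]2OC[C@@H](O)[C@H]2OC1`: > 16000 nM

Among these three results compound 1 stands alone as the only actual number, since in this assay compound 1 gives 4070 nM. For compound 2 the result is a limit of the assay rather than a number, > 8000 nM. For compound 3 the result is also a limit of the assay, > 16000 nM. Going by the values given here, the single step between two measured compounds, a step that the two limits leave unreadable from compound 2 to compound 3, is unreadable because the limit of > 8000 nM in this assay, at which 1 of the 3 values shown sits, and the limit of > 16000 nM in this assay, at which 1 of the 3 values shown sits, hold both of its ends. Compound 4 `O=C1C=C(NCc2ccccc2)C(=O)c2c1nc1n2[C@H]2OC[C@@H](O)[C@H]2OC1` differs from compound 1 by benzyl in place of 4-iodophenyl on an amine nitrogen. Among the compounds with values here, no measured step touches the amine substituent in this way, so nothing measured bears on the change, and no direction can be expected with confidence. The step from compound 1 to compound 4 is therefore estimated to lie near the scatter, with a wide range around it, as a 1.5-fold higher number from compound 1 to compound 4 (0.17 log units; within the scatter). Compound 4 is expected to give about 6000 nM, between 1500 nM and 20000 nM.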

Compound 4, half-maximal inhibitory concentration: > 8000 nM
Compound 4 was reported as a limit (the forecaster's own chance of this, stated with the estimate: 40%); middle value at least 1.3-fold (0.12 log units) from the limit.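

Going by these compounds alone, this is the first readable step at the amine substituent: in this assay, benzyl in place of 4-iodophenyl on the amine nitrogen gives an at least 1.9-fold higher number from compound 1 to compound 4 (0.29 log units; that floor lies within the scatter). Within the data shown here, both groups carry one six-membered aromatic ring of carbon only, so the swap keeps that ring while removing the iodine and changing how the ring is attached to the nitrogen, yet compound 4 gives no actual number, which leaves compound 1 as the only compound with one. The real size of the step cannot be read because the result for compound 4 is a limit of the assay: the limit of > 8000 nM in this assay, at which 2 of the 4 values shown sit.

The compounds shown leave open whether losing the iodine or moving from an aryl to a benzyl group matters more, and a plain phenyl or a 4-iodobenzyl on the amine nitrogen would separate the two. As far as these compounds go, how a longer chain such as 2-phenylethyl would read also remains open.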